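The source may report more compounds than this note shows. Statements on the series, on what has been measured and on what is new or still open speak of the compounds shown alone.

Measured compounds in a functional assay on DU-145 cells (Homo sapiens) for inhibition, read by trypan blue exclusion, with a stated time of 96 h; a higher number here means a weaker inhibitor of growth, a lower number a stronger inhibitor of growth:
- compound 1 `O=C(/C(=C\c1csc([N+](=O)[O-])c1)S(=O)(=O)c1ccc(Br)cc1)c1ccc(Br)cc1`: 1000 nM
- compound 2 `O=C(/C(=C\c1ccc(I)cc1)S(=O)(=O)c1ccc(Br)cc1)c1ccc(Br)cc1`: 1000 nM
- compound 3 `O=C(/C(=C\c1ccc(Cl)cc1Cl)S(=O)(=O)c1ccc(Br)cc1)c1ccc(Br)cc1`: 10000 nM

Compound 3 gives the highest number of the three in this assay. Its nearest neighbours are compound 1 and compound 2, which lie within the scatter of each other, as the step of no change at the digits printed from compound 1 to compound 2 (within the scatter) shows. Both steps into compound 3 go the same way: a 10-fold higher number from compound 1 to compound 3 (1.00 log units; beyond the scatter) and a 10-fold higher number from compound 2 to compound 3 (1.00 log units; beyond the scatter). Within these three compounds, 2,4-dichlorophenyl on the double-bonded chain carbon is therefore the only group linked to a weaker growth inhibitor.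

Compound 4 `O=C(/C(=C\c1ccc(F)cc1)S(=O)(=O)c1ccc(Br)cc1)c1ccc(Br)cc1` differs from compound 3 in one place: 4-fluorophenyl in place of 2,4-dichlorophenyl on a double-bonded chain carbon bound to a double-bonded chain carbon. The two measured steps that bear on this change are those leading into compound 3, both of which remove or install 2,4-dichlorophenyl at this position. Compound 4 reverses that installation, and 4-fluorophenyl resembles the 4-iodophenyl of compound 2 more closely than the 2,4-dichlorophenyl of compound 3, so a step of roughly the same size back down is expected in this assay. The estimate for compound 4 in this assay is therefore 1000 nM, with a range of 300 nM to 4000 nM, which means an expected step of a 10-fold lower number from compound 3 to compound 4 (1.00 log units; beyond the scatter). Among the compounds with values here, there is no measured 4-fluorophenyl analogue to check this against, and the expected number is taken from compound 2 at 1000 nM.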

Compound 4, concentration for 50% growth inhibition: 4000 nM
Compound 4: middle estimate off by 4.0-fold (0.60 log units), on the low side, and the stated range covers the measured number.
By their numbers in this assay, from the lowest: compounds 1 and 2 (each within the scatter of the next); then compound 4; then compound 3.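

In this assay, within the data shown here, the identity of the single halogen on this aromatic carbon matters, with fluoro in place of iodo giving a 4.0-fold higher number from compound 2 to compound 4 (0.60 log units; beyond the scatter) and the earlier compounds offering no such halogen-only change. The same position also separates 4-fluorophenyl from 5-nitrothiophen-3-yl, as a 4.0-fold higher number from compound 1 to compound 4 (0.60 log units; beyond the scatter) shows, so the match between compound 1 and compound 2 does not extend to every group tried here. Leaving 2,4-dichlorophenyl for 4-fluorophenyl gives a 2.5-fold lower number from compound 3 to compound 4 (0.40 log units; beyond the scatter) and places compound 4 on a third level, so 2,4-dichlorophenyl is no longer the only group linked to a weaker growth inhibitor, although no measurement at hand explains any of these steps.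

The compounds shown leave open whether 4-chlorophenyl would sit with compound 4 or with compound 3, which would help separate the effect of the halogen from that of the second chlorine. They also leave open how an amine or a carboxylic acid on the phenyl ring at this position would behave, and whether these steps hold when the two 4-bromophenyl groups of the shared core are replaced.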